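The compounds below may be only part of what the source reports. "The series", "measured", "known", "first", "only" and "open" are said of these compounds alone.

Measured in a physicochemical assay for solubility, in phosphate buffer, at pH 7.4; a higher number here means a more soluble compound, a lower number a less soluble compound:
Compound 1 `CC(C)n1cc(-c2ccnc3[nH]c(C4CCN(CC(=O)N(C)C)CC4)cc23)ccc1=O`: 110000 nM
Compound 2 `CN(C)C(=O)CN1CCC(c2cc3c(-c4ccc(=O)n(CCC5CCOCC5)c4)ccnc3[nH]2)CC1`: 370000 nM
Compound 3 `COc1cc(=O)n(C)cc1-c1ccnc2[nH]c(C3CCN(CC(=O)N(C)C)CC3)cc12`: 670000 nM

Compound 3 lies within the usual scatter of compound 2, and both stand clear of compound 1. Compound 4 `CN(C)C(=O)CN1CCC(c2cc3c(-c4ccc(=O)n(C)c4)ccnc3[nH]2)CC1` differs from compound 3 by one change, (hydrogen in place of methoxy on an aromatic carbon), that is, hydrogen in place of methoxy on an aromatic carbon. The nearest measured evidence is a 6.1-fold higher number from compound 1 to compound 3 (0.78 log units; beyond the scatter), but that step also swaps the group on the ring nitrogen. Such a swap alone gave a 3.4-fold higher number from compound 1 to compound 2 (0.53 log units; beyond the scatter), so the methoxy share of the first step cannot be separated out. Losing the methoxy may undo part of that rise, so only a small fall is expected in this assay, possibly none beyond the scatter. The expected change is a 1.9-fold lower number from compound 3 to compound 4 (0.28 log units; within the scatter). Compound 4 is estimated at 350000 nM, within an expected range from 130000 nM to 800000 nM.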

Compound 4, solubility: > 1000000 nM
Compound 4: only a limit was reported; the forecaster's own chance of this, stated with the estimate: 5%; middle value at least 2.8-fold (0.45 log units) away from the limit.
By their numbers in this assay, from the lowest: compound 1; then compounds 2 and 3 (each within the scatter of the next). At a limit, above all of these: compound 4.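

In this assay hydrogen in place of methoxy gives an at least 1.4-fold higher number from compound 3 to compound 4 (0.17 log units; that floor lies within the scatter) and so the methoxy opposite the ring nitrogen is not needed to keep the number high. On the ring nitrogen, methyl in place of isopropyl gives an at least 9.0-fold higher number from compound 1 to compound 4 (0.95 log units; beyond the scatter) and hydrogen in place of (oxan-4-yl)methyl gives an at least 2.7-fold higher number from compound 2 to compound 4 (0.43 log units; beyond the scatter) so methyl stands clear of both other groups shown there. Compound 4 carries only a limit, not a number: the limit of > 1000000 nM in this assay, at which 1 of the 4 values shown sits.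

Going by these compounds, how far compound 4 truly lies above compound 3 stays open. So does whether an amine or a carboxylic acid on that aromatic carbon would keep the number as high.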